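The source may report more compounds than this note shows. Statements on the series, on what has been measured and on what is new or still open speak of the compounds shown alone.

Measured compounds in a functional assay on SK-OV-3 cells (Homo sapiens) for cytotoxicity, read by MTT assay, with a stated time of 48 h; on this read-out higher numbers stand for weaker inhibition and lower numbers for stronger inhibition:
- compound 1 `COc1ccc2[nH]c(=O)c(-c3nc4cc(C)c(C)cc4[nH]3)cc2c1`; in this assay compound 1 gives > 100000 nM, a limit of the assay rather than a number.
- compound 2 `O=c1[nH]c2ccccc2cc1-c1nc2cc([N+](=O)[O-])ccc2[nH]1`; in this assay compound 2 gives > 100000 nM, again a limit.
- compound 3 `COc1ccc2[nH]c(=O)c(-c3nc4cc(Cl)ccc4[nH]3)cc2c1`; in this assay compound 3 gives > 100000 nM, also a limit.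

Compound 3 therefore stands nowhere in particular among the numbers shown: no compound in this set returns a numeric half-maximal inhibitory concentration, and the three values cannot be ordered against one another. All that is known is the limit of > 100000 nM in this assay, at which 3 of the 3 values shown sit.

Compound 4 `COc1ccc2[nH]c(=O)c(-c3nc4ccccc4[nH]3)cc2c1` is the next member to be measured. It differs from compound 3 in one place: hydrogen in place of chloro on an aromatic carbon. Among the measured compounds shown here, with no measured step available between any two compounds, and with every value in the set sitting at the same limit, no direction for the change can be read from the data. The expectation is no step beyond the scatter, so that from compound 3 to compound 4 the estimated change is a step that the limit leaves unreadable from compound 3 to compound 4. Compound 4 is accordingly expected to give about 150000 nM in this assay, within roughly 30000 nM to 1000000 nM, most probably again reported only as a limit.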

Compound 4, half-maximal inhibitory concentration: > 100000 nM
Compound 4 gave a limit, no number (the forecaster's own chance of this, stated with the estimate: 80%); the middle value does not contradict the limit.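

No step can be read from compound 3 to compound 4, because both values are limits rather than numbers: the limit of > 100000 nM in this assay, at which 4 of the 4 values shown sit.

The compounds shown leave open whether any member of this series returns a numeric half-maximal inhibitory concentration, and what hydrogen in place of chloro does to that read-out.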